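Hydrazone series: methylamino extension on the pyridyl methyl

This account rests on a few compounds, and the source may have more. Where it says the series, first, only, none or still open, it means among the compounds named here.

Measured so far:
Compound 1 `Cc1ccc(/C=N\Nc2ncnc3sc(C(C)(C)C)cc23)nc1`: 0.009 ug/mL
Compound 2 `Cc1cccc(/C=N\Nc2ncnc3sc(C(C)(C)C)cc23)n1`: 0.258 ug/mL

Within the data shown here, in a functional assay on PC-6 cells (Homo sapiens) for antiproliferative activity (on this read-out higher numbers stand for weaker inhibition and lower numbers for stronger inhibition), compound 2 gives the higher of the two numbers; the single measured step, a 29-fold higher number from compound 1 to compound 2 (1.46 log units; beyond the scatter), moved the methyl on the pyridyl ring and nothing else. Compound 3 `CNCc1cccc(/C=N\Nc2ncnc3sc(C(C)(C)C)cc23)n1` differs from compound 2 by methylamino in place of hydrogen on a saturated chain carbon bound to an aromatic carbon. Among the measured compounds shown here, no measured step touches this change, so the expectation rests on compound 2 alone: a step of a 1.0-fold lower number from compound 2 to compound 3 (0.01 log units; within the scatter), not beyond the scatter, is expected. For compound 3 the estimated value is 0.25 ug/mL, with a range from 0.05 ug/mL to 1.2 ug/mL.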

Compound 3, half-maximal inhibitory concentration: 0.189 ug/mL
Compound 3: middle estimate off by 1.3-fold (0.12 log units), on the high side, within the range that was stated.
By their numbers in this assay, from the lowest: compound 1; then compounds 3 and 2 (each within the scatter of the next).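

In this assay the change from methyl to (methylamino)methyl gives a 1.4-fold lower number from compound 2 to compound 3 (0.14 log units; within the scatter) and so shows that this saturated chain carbon bound to an aromatic carbon can carry methylamino with no shift beyond the scatter. The earlier step concerned only where the methyl sat, whereas this one shows the methyl itself can be extended. No available evidence bears on why this step stays so small.

Going by these compounds, whether a longer chain, a dimethylamino group or a carboxylic acid at this carbon would also stay within the scatter remains open. Also open, on these data alone, is whether (methylamino)methyl would do the same on the 5-methylpyridin-2-yl of compound 1.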